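This account rests on a few compounds, and the source may have more. Where it says the series, first, only, none or still open, it means among the compounds named here.

In a functional assay on MCF7 cells (Homo sapiens) for activation, with a stated time of 20 h (on this read-out higher numbers stand for weaker inhibition and lower numbers for stronger inhibition), compound 1 `CNc1nc2ccn(C)c(=O)c(Cc3ccc(OC)cc3)c-2n1` gives > 50 ug/mL, which is a limit of the assay and not a number. Going by the values given here, compound 2 `CNc1nc2ccn(C)c(=O)c(Cc3cc(C)c(OC)c(C)c3)c-2n1` gives 3.5 ug/mL, the only true number so far. Compound 3 `COc1c(C)cc(Cc2c3nc(N(C)C)nc-3ccn(C)c2=O)cc1C` differs from compound 2 by methyl in place of hydrogen on a nitrogen on an aromatic ring, turning methylamino into dimethylamino. Among the compounds with values here, no measured step shows what this change does, so only a small shift is expected, perhaps toward weaker inhibition. The estimated step of a 1.4-fold higher number from compound 2 to compound 3 (0.15 log units; within the scatter) stays within the usual scatter. For compound 3 the expected value is 5 ug/mL, with an estimated range of 1.5 ug/mL to 20 ug/mL.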

Compound 3, half-maximal inhibitory concentration: 3 ug/mL
Compound 3: the middle estimate sits 1.7-fold (0.22 log units) above what was measured; the range from low to high includes it.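

In this assay, going by these compounds alone, the methyl that turns methylamino into dimethylamino gives a 1.2-fold lower number from compound 2 to compound 3 (0.07 log units; within the scatter) as the first measured step in this set, something compound 1 and compound 2 alone could not show. The hydrogen on this nitrogen can therefore be replaced by methyl while the two compounds stay level. Nothing measured here gives a reason for this result.

Still open, on these data alone, is whether a larger group on this nitrogen, such as ethyl or a longer chain, would also leave the value in place. The same question holds for a free amine at this position.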